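The source may hold more compounds than are shown below. What is called first, only, known or untested is meant among the compounds shown, and "the series" means these compounds.

Measured in an ADME assay on the whole organism (Rattus norvegicus, strain Sprague-Dawley) for pharmacokinetics, read by LC-MS, with a stated time of 24 h, at a dose of 1 mg/kg by the intravenous route; a higher number here means faster removal of the compound, a lower number slower removal:

- Compound 1 `CCN1C(=O)COc2c(CN3CCN(C(C)=O)CC3)cc(Nc3ncc(F)c(-c4ccc(F)cc4OC)n3)cc21`: 50.2 mL/min/kg
- Compound 2 `CCN1C(=O)COc2c(CN3CCN(S(C)(=O)=O)CC3)cc(Nc3ncc(F)c(-c4ccc(F)cc4OC)n3)cc21`: 68.1 mL/min/kg

Compound 2 stands within the scatter of compound 1. Among the measured compounds shown here, the only measured step, a 1.4-fold higher number from compound 1 to compound 2 (0.13 log units; within the scatter), is methylsulfonyl in place of acetyl on an amine nitrogen in a ring. Compound 3 `CCN(CC)Cc1cc(Nc2ncc(F)c(-c3ccc(F)cc3OC)n2)cc2c1OCC(=O)N2CC` differs from compound 2 by diethylamino in place of 4-(methylsulfonyl)piperazin-1-yl on a saturated chain carbon bound to an aromatic carbon, with diethylamino in place of 4-(methylsulfonyl)piperazin-1-yl on a saturated chain carbon bound to an aromatic carbon. For the measured compounds named here, the measured step bears on this only loosely, as it keeps the ring that now leaves, and no measured compound lacks that ring. Going by the values given here, with only that small step, a 1.4-fold higher number from compound 1 to compound 2 (0.13 log units; within the scatter), as a guide, no step beyond the scatter is expected in this assay, and the direction stays open. The estimated step is a 1.0-fold lower number from compound 2 to compound 3 (0.02 log units; within the scatter). For compound 3 the expected clearance is 65 mL/min/kg, with an estimated range of 36 mL/min/kg to 110 mL/min/kg.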

Compound 3, clearance: 168 mL/min/kg
The estimate for compound 3 lay 2.6-fold (0.41 log units) below the measured number; measured number outside the range, above it.
By their numbers in this assay, from the lowest: compounds 1 and 2 (each within the scatter of the next); then compound 3.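

In this assay, this place, on a saturated chain carbon bound to an aromatic carbon, now shows a step beyond the scatter: diethylamino in place of 4-(methylsulfonyl)piperazin-1-yl gives a 2.5-fold higher number from compound 2 to compound 3 (0.39 log units; beyond the scatter), and diethylamino in place of 4-acetylpiperazin-1-yl gives a 3.3-fold higher number from compound 1 to compound 3 (0.52 log units; beyond the scatter). The earlier step only exchanged the group on the ring nitrogen and stayed within the scatter, whereas replacing the whole ring with the open diethylamino group comes with the higher number from either ring compound. No evidence at hand accounts for this rise.

The compounds shown leave open whether the ring itself matters or only the acetyl and methylsulfonyl piperazine groups. A piperidin-1-yl or morpholin-4-yl group at this place could separate these readings, and dimethylamino would test whether the ethyl chains take part.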